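The source may report more compounds than this note shows. Statements on the series, on what has been measured and on what is new or still open speak of the compounds shown alone.

Measured compounds in a functional assay on MGC-803 cells (Homo sapiens) for cytotoxicity, read by MTT assay, with a stated time of 72 h; on this read-out higher numbers stand for weaker inhibition and lower numbers for stronger inhibition:
compound 1 `O=C1C(=Cc2ccc(O)cc2)C(=O)N(c2ccc(Cl)cc2)N1c1ccc(Cl)cc1` gives 19500 nM
compound 2 `O=C1C(=Cc2ccc(F)cc2)C(=O)N(c2ccc(Cl)cc2)N1c1ccc(Cl)cc1` gives 26000 nM

Compound 1 has the lowest of the two numbers, but its nearest neighbour, compound 2, sits within the scatter of it, as shown by a 1.3-fold higher number from compound 1 to compound 2 (0.12 log units; within the scatter), which brings fluoro in place of hydroxy on an aromatic carbon.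

Compound 3 `O=C1C(=C/C=C/c2ccccc2)C(=O)N(c2ccc(Cl)cc2)N1c1ccc(Cl)cc1` has not been measured. It differs from compound 1 by 2-phenylethenyl in place of 4-hydroxyphenyl on a double-bonded chain carbon bound to a double-bonded ring carbon. For the measured compounds named here, the only measured step, the one from compound 1 to compound 2, concerns the group on the aromatic ring and not the replacement of the ring itself by a 2-phenylethenyl chain, so it bears on this change only loosely: it shows that losing the hydroxy group left this assay unmoved beyond the scatter. Going by the values given here, no measured step covers the chain extension. Compound 3 is therefore expected to give about 20000 nM, between 7000 nM and 60000 nM, with an expected step of a 1.0-fold higher number from compound 1 to compound 3 (0.01 log units; within the scatter).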

Compound 3, half-maximal inhibitory concentration: 5100 nM
For compound 3 the middle estimate is 3.9-fold (0.59 log units) above the measured one, outside the stated range (below it).
By their numbers in this assay, from the lowest: compound 3; then compounds 1 and 2 (each within the scatter of the next).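

In this assay, the earlier pair showed only that fluoro in place of hydroxy on an aromatic carbon left the number within the scatter, so it said nothing about how far this position could respond. Placing 2-phenylethenyl on the double-bonded chain carbon bound to a double-bonded ring carbon gives the first changes beyond the scatter: a 3.8-fold lower number from compound 1 to compound 3 (0.58 log units; beyond the scatter) when it replaces 4-hydroxyphenyl and a 5.1-fold lower number from compound 2 to compound 3 (0.71 log units; beyond the scatter) when it replaces 4-fluorophenyl, both modest and both toward stronger inhibition. Nothing available gives a reason for this shift.

The compounds shown leave open whether hydroxy or fluoro on the aromatic ring of the 2-phenylethenyl group would matter as little as it does on the directly attached ring. They also leave open whether a longer chain with further double bonds, or an amine on that ring, would move the number further.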